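Sulfonamide capping in the trimethyllysine peptide series

A few compounds are considered here, and "the series" means these few. Any claim that something is new, unique, unknown or untested is made for them only; others in the source may bear on it.

Compound 1 `CC(C)C[C@H](NC(=O)[C@H](C)NC(=O)c1ccccc1)C(=O)N[C@@H](CCCC[N+](C)(C)C)C(=O)N[C@@H](CO)C(N)=O` carries a benzoyl group on the amine nitrogen; in an assay on isolated protein for displacement of a labelled ligand from Chromobox protein homolog 7 (Homo sapiens), read by fluorescence polarization, with a stated time of 15 min (a lower number here means a stronger inhibitor, a higher number a weaker inhibitor), compound 1 gives 57000 nM. Compound 2 `CC(C)C[C@H](NC(=O)[C@H](C)NC(=O)CCc1ccccc1)C(=O)N[C@@H](CCCC[N+](C)(C)C)C(=O)N[C@@H](CO)C(N)=O` has phenethyl in place of phenyl on the carbonyl carbon, and in this assay compound 2 gives 26000 nM; that step reads a 2.2-fold lower number from compound 1 to compound 2 (0.34 log units; beyond the scatter). Compound 3 `COc1ccc(S(=O)(=O)N[C@@H](C)C(=O)N[C@@H](CC(C)C)C(=O)N[C@@H](CCCC[N+](C)(C)C)C(=O)N[C@@H](CO)C(N)=O)cc1` replaces the amide cap with a (4-methoxyphenyl)sulfonyl on the amine nitrogen. In this assay compound 3 gives only a limit, > 250000 nM, so compound 3 stands at the weak end of the set without a number of its own. The steps into it read an at least 4.3-fold higher number from compound 1 to compound 3 (0.64 log units; beyond the scatter) and an at least 9.6-fold higher number from compound 2 to compound 3 (0.98 log units; beyond the scatter), both against the sulfonamide cap; their size is bounded from one side only because of the limit of > 250000 nM in this assay, at which 1 of the 3 values shown sits.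

Compound 4 `CC(C)C[C@H](NC(=O)[C@H](C)NS(=O)(=O)c1cccnc1)C(=O)N[C@@H](CCCC[N+](C)(C)C)C(=O)N[C@@H](CO)C(N)=O` keeps the sulfonamide and changes the aryl: pyridin-3-yl in place of 4-methoxyphenyl on a sulfonyl sulfur. Among the compounds with values here, no measured step here alters the aryl ring on a sulfonyl sulfur, so the two steps into compound 3 are the only guide, and they say just that a sulfonamide cap sits at or past the limit. Expected: compound 4 remains near that limit, the step of a number no higher from compound 3 to compound 4 (the limit leaves the size open) being none beyond the scatter. Estimate for compound 4 in this assay: 250000 nM, between 80000 nM and 800000 nM.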

Compound 4, half-maximal inhibitory concentration: > 250000 nM
Compound 4: no number, only a limit; the forecaster's own chance of this, stated with the estimate: 70%; the middle value sits exactly at the limit.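

With pyridin-3-yl in place of 4-methoxyphenyl on the sulfonyl sulfur, the sulfonamide cap still gives no number in this assay: compound 4 gives > 250000 nM, which is a limit of the assay and not a measured potency. Against the amide caps, the second sulfonamide reads an at least 4.3-fold higher number from compound 1 to compound 4 (0.64 log units; beyond the scatter) and an at least 9.6-fold higher number from compound 2 to compound 4 (0.98 log units; beyond the scatter), so in these two sulfonamides the shift to the weak end does not depend on the 4-methoxyphenyl group alone. The step from compound 3 to compound 4 cannot be read, because both compounds sit at the same limit: the limit of > 250000 nM in this assay, at which 2 of the 4 values shown sit.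

On these data alone, how far either sulfonamide lies past that limit remains unknown, and so does whether the change of aryl group has any effect on binding. Also open, as far as these compounds go, is whether a sulfonyl cap without an aromatic ring, such as methylsulfonyl, or one with a carbon chain on the sulfur, such as benzylsulfonyl or phenethylsulfonyl, would return a readable value in this assay.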